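The compounds below may be only part of what the source reports. "The series", "measured", "known", "first", "only" and "open" are said of these compounds alone.

Of the compounds shown here, two with a shared core have so far been measured in a functional assay on HeLa cells (Homo sapiens) for cytotoxicity, read by MTT assay, with a stated time of 48 h, in the absence of a further agent; on this read-out higher numbers stand for weaker inhibition and lower numbers for stronger inhibition. Compound 1 `COc1ccc2[nH]cc(-c3nc(C(=O)Nc4cc(OC)c(OC)c(OC)c4)cs3)c2c1` gives 29600 nM in this assay, the highest of the two numbers. Compound 2 `O=C(NCc1ccccc1)c1csc(-c2c[nH]c3ccccc23)n1` gives 9510 nM in this assay, a lower number than that of compound 1, with a gap between them beyond the usual scatter; since the two structures differ in more than one place, only the two values themselves can be stated for this pair.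

The next compound, compound 3 `COc1cc(NC(=O)c2csc(-c3c[nH]c4ccc(F)cc34)n2)cc(OC)c1OC`, has not yet been measured in this assay. It differs from compound 1 in one place: fluoro in place of methoxy on an aromatic carbon. Among the compounds with values here, no pair of measured compounds shows what this exchange does in this assay, so its effect here is unknown. On the numbers at hand the exchange is expected to move the value by a 1.5-fold lower number from compound 1 to compound 3 (0.17 log units; within the scatter), a step small enough that it may not rise beyond the scatter in either direction. Compound 3 is therefore estimated to give 20000 nM in this assay, within a range from 6000 nM to 60000 nM.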

Compound 3, half-maximal inhibitory concentration: > 100000 nM
Compound 3: no number, only a limit; the forecaster's own chance of this, stated with the estimate: 10%; at least 5.0-fold (0.69 log units) between middle value and limit.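

In this assay, fluoro in place of methoxy on this aromatic carbon, meta to a fused ring and para to a fused ring, gives an at least 3.3-fold higher number from compound 1 to compound 3 (0.52 log units; beyond the scatter), the first step read at this position, and it shows that the position is not indifferent to the group it carries. Compound 3 gives > 100000 nM, which is a limit of the assay and not a number. The step therefore fixes a direction and a smallest size but no full size, and the value of compound 3 stands at the limit of the assay: the limit of > 100000 nM in this assay, at which 1 of the 3 values shown sits.

Only methoxy and fluoro are shown on this carbon, so it remains open whether the loss of methoxy or the arrival of fluoro matters more, and how hydrogen, chloro, ethoxy or an amine would stand there. The step also comes from a single pair, which leaves unknown whether the same exchange would move the value in the same direction with a different group elsewhere on the shared core.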